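Swapping Chloro for Fluoro on Compound 1

This account rests on a few compounds, and the source may have more. Where it says the series, first, only, none or still open, it means among the compounds named here.

Compound 1 `COc1ccc2[nH]c(=O)c(-c3nc4cc(F)ccc4[nH]3)cc2c1`: > 100000 nM (a limit of the assay)
Compound 2 `O=c1[nH]c2ccccc2cc1-c1nc2cc(F)ccc2[nH]1`: 24200 nM
Compound 3 `COc1ccc2[nH]c(=O)c(-c3nc4cc(C)c(C)cc4[nH]3)cc2c1`: > 100000 nM (a limit of the assay)

All three compounds were tested in a functional assay on NCI-H460 cells (Homo sapiens) for cytotoxicity, read by MTT assay, with a stated time of 48 h; a lower number here means a stronger inhibitor, a higher number a weaker inhibitor. Compound 1 gives > 100000 nM in this assay, which is a limit of the assay and not a measured number. Compound 3 likewise gives > 100000 nM, again a limit. Compound 2 gives 24200 nM. Within the data shown here, the one step between compounds that differ in a single place is an at least 4.1-fold lower number from compound 1 to compound 2 (0.61 log units; beyond the scatter). Where compound 1 stands is described by the limit of > 100000 nM in this assay, at which 2 of the 3 values shown sit, so it sits at the edge of what the assay can report.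

Compound 4 `COc1ccc2[nH]c(=O)c(-c3nc4cc(Cl)ccc4[nH]3)cc2c1` differs from compound 1 in one place: chloro in place of fluoro on an aromatic carbon. Among the measured compounds shown here, no measured pair exchanges one halogen for another, so the step from compound 1 to compound 2 bears on this change only indirectly: it shows that removing the methoxy moved compound 1 off the limit, but says nothing about the fluoro position. With chloro and fluoro each counted as a single heavy atom without donors or acceptors, no step beyond the scatter is expected in this assay. Compound 4 is therefore estimated at 100000 nM, with a range of 35000 nM to 300000 nM. The expected step is a number no higher from compound 1 to compound 4 (the limit leaves the size open), and the result may again be reported only as a limit.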

Compound 4, half-maximal inhibitory concentration: > 100000 nM
Compound 4 was reported as a limit (the forecaster's own chance of this, stated with the estimate: 60%); the middle value lies on the limit itself.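

No step can be read from compound 1 to compound 4 in this assay, because both compounds are reported only as limits of the assay and not as numbers: the limit of > 100000 nM in this assay, at which 3 of the 4 values shown sit.

The compounds shown leave open how chloro and fluoro compare on the shared core, and whether chloro would change the number when the methoxy is absent, as it is in compound 2.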